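Adding a bromo group to the methoxy pyridine

A few compounds are considered here, and "the series" means these few. Any claim that something is new, unique, unknown or untested is made for them only; others in the source may bear on it.

Measured so far:
compound 1, `Brc1cc(N2CC[C@H]3CN[C@H]3C2)cnc1Br` — 7.8 nM
compound 2, `COc1cncc(N2CC[C@H]3CN[C@H]3C2)c1` — 130 nM

In a functional assay on HEK293 cells for agonist activity at Neuronal acetylcholine receptor; alpha4/beta2 (Homo sapiens), read by FLIPR (a higher number here means that more compound is needed for the effect, a lower number that less compound is needed), compound 1 gives 7.8 nM and compound 2 gives 130 nM, so compound 2 stands with the higher of the two numbers, a gap beyond the usual scatter. Compound 3, `COc1cc(N2CC[C@H]3CN[C@H]3C2)cnc1Br`, is not yet measured. It differs from compound 2 by bromo in place of hydrogen on an aromatic carbon, next to the ring nitrogen, as in compound 1. Since compound 1 with its bromo there gives 7.8 nM, the number for compound 3 is expected to drop, a step of about a 5.2-fold lower number from compound 2 to compound 3 (0.72 log units; beyond the scatter). Compound 3 is estimated at 25 nM, within 8 nM to 80 nM.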

Compound 3, half-maximal effective concentration: 21 nM
Estimate against measurement, compound 3: 1.2-fold (0.08 log units) above, and the stated range covers the measured number.
By their numbers in this assay, from the lowest: compound 1; then compound 3; then compound 2.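

In this assay, bromo in place of hydrogen next to the ring nitrogen gives a 6.2-fold lower number from compound 2 to compound 3 (0.79 log units; beyond the scatter), so this one atom matters even with the methoxy group kept. Methoxy in place of bromo on an aromatic carbon gives a 2.7-fold higher number from compound 1 to compound 3 (0.43 log units; beyond the scatter), which shows that the second group also counts once this bromo is present. Nothing available explains either step. From the compounds shown here alone, whether chloro or an amine in the place of this bromo would give a similar number remains open, as does the effect of a longer ether chain in place of methoxy.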